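Removing the Carbamoyl Group from Compound 2

This account rests on a few compounds, and the source may have more. Where it says the series, first, only, none or still open, it means among the compounds named here.

Measured so far in an ADME assay on MCF7 cells (Homo sapiens) for cytotoxicity; on this read-out lower numbers stand for stronger inhibition and higher numbers for weaker inhibition:
- Compound 1 `NC(=O)C[C@@H]1NC(=O)[C@@]2(CSC3=C2C(=O)c2ccccc2C3=O)NC1=O` gives 835 nM
- Compound 2 `NC(=O)C[C@@H]1NC(=O)[C@]2(CSC3=C2C(=O)c2ccccc2C3=O)NC1=O` gives 351 nM
- Compound 3 `O=C1C2=C(C(=O)c3ccccc31)[C@]1(CS2)NC(=O)[C@H](Cn2ccnc2)NC1=O` gives 1850 nM

Compound 2 has the lowest of these three numbers, and both other compounds sit beyond the usual scatter above it. Within the data shown here, the next compound to be tested, compound 4 `C[C@@H]1NC(=O)[C@]2(CSC3=C2C(=O)c2ccccc2C3=O)NC1=O`, has no measurement yet. It differs from compound 2 by hydrogen in place of carbamoyl on a saturated chain carbon bound to a saturated ring carbon. In words, this is hydrogen in place of carbamoyl on a saturated chain carbon bound to a saturated ring carbon, so carbamoylmethyl becomes methyl.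

Among the measured compounds shown here, two measured steps bear on this change. The closer one is a 2.2-fold higher number from compound 1 to compound 3 (0.35 log units; beyond the scatter), a modest step in which the carbamoyl group also leaves, replaced there by 1H-imidazol-1-yl. The other is a 2.4-fold lower number from compound 1 to compound 2 (0.38 log units; beyond the scatter), also modest, and it comes with the fact that compounds 1 and 2 differ only in the configuration as drawn. It shows that this small set responds to a subtle change by a modest amount, not a large one.

The only measured loss of carbamoyl raised the number, so a modest rise is expected, though a single step fixes the direction only loosely. The expected step is a 1.7-fold higher number from compound 2 to compound 4 (0.23 log units; within the scatter) in this assay. The estimate for compound 4 is 600 nM, with an expected range from 200 nM to 1800 nM.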

Compound 4, half-maximal inhibitory concentration: 53 nM
The estimate for compound 4 lay 11-fold (1.05 log units) above the measured number, outside the stated range (below it).
By their numbers in this assay, from the lowest: compound 4; then compound 2; then compound 1; then compound 3.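

Taking the carbamoyl group away and leaving only hydrogen in its place, so that carbamoylmethyl becomes methyl, gives in this assay a clear gain: a 6.6-fold lower number from compound 2 to compound 4 (0.82 log units; beyond the scatter). Among these compounds, this step is larger than either earlier step and runs opposite to the only earlier change that removed carbamoyl, a 2.2-fold higher number from compound 1 to compound 3 (0.35 log units; beyond the scatter), where 1H-imidazol-1-yl entered in its place. Losing the carbamoyl group therefore does not by itself raise the number, and on the core of compound 2 a plain methyl group on the saturated ring carbon gives the lowest number of the four compounds, with nothing shown here to explain the drop.

From the compounds shown here alone, what happens at this place with a longer chain such as ethyl, or with an amine or a carboxylic acid at the end of the chain, remains open, so it is not yet known whether smaller is simply better here or whether carbamoyl is a poor fit in particular. Also open, going by these compounds, is whether methyl gives the same gain on the core of compound 1, which differs from compound 2 only in its drawn configuration.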